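Thiourea in Place of Urea on a Sulfonamide Core

This account rests on a few compounds, and the source may have more. Where it says the series, first, only, none or still open, it means among the compounds named here.

Compound 1 `O=C(NCCNS(=O)(=O)c1ccc(-c2ccccc2OCc2cccc(O)c2)s1)Nc1cc(Cl)cc(Cl)c1` was tested in a functional assay on RS4-11 cells (Homo sapiens) for inhibition, read by CCK-8 assay, with a stated time of 48 h; on this read-out lower numbers stand for stronger inhibition and higher numbers for weaker inhibition. In this assay compound 1 gives only a limit, > 50000 nM, so it stands at the limit of > 50000 nM in this assay, at which 1 of the 2 values shown sits, and not at a number. Compound 2 `O=C(NCCNS(=O)(=O)c1ccc(-c2ccccc2Oc2ccc([N+](=O)[O-])c([N+](=O)[O-])c2)s1)Nc1cc(Cl)cc(Cl)c1` gives 2100 nM in this assay. For the measured compounds named here, the single measured step, an at least 23-fold lower number from compound 1 to compound 2 (1.37 log units; beyond the scatter), alters the group on the ring oxygen, not the amine nitrogen. Compound 3 `O=[N+]([O-])c1ccc(NC(=S)NCCNS(=O)(=O)c2ccc(-c3ccccc3OCc3cccc(O)c3)s2)cc1` differs from compound 1 by a group of 12 heavy atoms (7 carbon, 2 nitrogen, 2 oxygen, 1 sulfur; one six-membered aromatic ring of carbon only) in place of a group of 11 heavy atoms (7 carbon, 1 nitrogen, 1 oxygen, 2 chlorine; one six-membered aromatic ring of carbon only), on an amine nitrogen. Going by the values given here, no measured step bears on this change, so the size and direction of the step in this assay are unknown. Compound 3 is therefore expected near 50000 nM, between 8000 nM and 300000 nM. This expectation corresponds to the step of a number no higher from compound 1 to compound 3 (the limit leaves the size open).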

Compound 3, half-maximal inhibitory concentration: 10100 nM
Compound 3: middle estimate off by 5.0-fold (0.69 log units), on the high side; low and high end bracket the measured number.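

The replacement on the amine nitrogen gives an at least 4.9-fold lower number from compound 1 to compound 3 (0.69 log units; beyond the scatter) in this assay, so this position also moves the number, as the ring oxygen did in the earlier step. Going by these compounds, that step stays open-ended, because compound 1 gives a limit and not a number: the limit of > 50000 nM in this assay, at which 1 of the 3 values shown sits.

The entering group differs from the (3,5-dichlorophenyl)carbamoyl group in both its sulfur and its ring substituent, and the compounds shown do not separate the two. On these data alone, whether a single chlorine or an amine on that aromatic ring would serve equally also stays open.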